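Smaller amine substituents and growth inhibition in a quinolinedione series

A few compounds are considered here, and "the series" means these few. Any claim that something is new, unique, unknown or untested is made for them only; others in the source may bear on it.

Of the compounds shown here, three of one shared core have been measured in a functional assay on NCI60 cells (Homo sapiens) for cytotoxicity; a higher number here means a weaker inhibitor of growth, a lower number a stronger inhibitor of growth. Compound 1 `COc1cc(-c2ccc3c(n2)C(=O)C=C(N2CC2)C3=O)cc(OC)c1OC` gives 589 nM, and compound 3 `C=CCNC1=CC(=O)c2nc(-c3ccccc3)ccc2C1=O` gives 1910 nM. Compound 2 `O=C1C=C(NCc2ccccc2)C(=O)c2nc(-c3ccccc3)ccc21` gives 33100 nM, the highest of the three numbers, with compound 3 nearest and compound 1 furthest, both gaps beyond the scatter. Compound 4 `COCCCNC1=CC(=O)c2ccc(-c3ccccc3)nc2C1=O` has not been measured. It differs from compound 2 in one place: 2-methoxyethyl in place of phenyl on a saturated chain carbon bound to an amine nitrogen. For the measured compounds named here, no measured pair shows this change directly, so the expectation rests on the two smaller-chain compounds giving lower numbers than compound 2. A drop beyond the scatter is expected, an 8.3-fold lower number from compound 2 to compound 4 (0.92 log units; beyond the scatter). Compound 4 is estimated at 4000 nM, within 1000 nM to 16000 nM.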

Compound 4, concentration for 50% growth inhibition: 5500 nM
Compound 4: the middle estimate sits 1.4-fold (0.14 log units) below what was measured; the measured number falls inside the stated range.
By their numbers in this assay, from the lowest: compound 1; then compound 3; then compound 4; then compound 2.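

In this assay, 2-methoxyethyl in place of phenyl gives a 6.0-fold lower number from compound 2 to compound 4 (0.78 log units; beyond the scatter). For the compounds shown here, this is the first direct reading at this position, and it shows that an aromatic ring on the saturated chain carbon bound to the amine nitrogen is not needed for growth inhibition. No measured evidence explains the step. The change removes the ring and brings in an oxygen together, and the compounds shown do not separate the two. A plain butyl chain, or a terminal amine or carboxylic acid on the chain, remains unplaced.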